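The source may report more compounds than this note shows. Statements on the series, on what has been measured and on what is new or still open speak of the compounds shown alone.

The compounds share one core, an aryl hydrazide carrying a morpholine sulfonyl group, and differ in the ring attached to the carbon with a double bond to nitrogen. In a functional assay on MGC-803 cells (Homo sapiens) for antiproliferative activity, read by MTT assay, with a stated time of 72 h (on this read-out higher numbers stand for weaker inhibition and lower numbers for stronger inhibition), compound 1 `C/C(=N\NC(=O)c1cccc(S(=O)(=O)N2CCOCC2)c1)c1cccc(N)c1O` gives 530 nM and compound 3 `CCN(CC)c1ccc(/C=N/NC(=O)c2cccc(S(=O)(=O)N3CCOCC3)c2)c(O)c1` gives 4040 nM. Compound 2 `O=C(N/N=C/c1ccco1)c1cccc(S(=O)(=O)N2CCOCC2)c1` gives only a limit in this assay, > 100000 nM, which marks the edge of what the assay can report rather than a measured number. Going by the values given here, compound 2 therefore sits at the limit of > 100000 nM in this assay, at which 1 of the 3 values shown sits, and is the one compound here for which no inhibition could be quantified.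

Compound 4 `CCOc1cccc(/C=N/NC(=O)c2cccc(S(=O)(=O)N3CCOCC3)c2)c1O` is not yet measured. It differs from compound 2 in one place: 3-ethoxy-2-hydroxyphenyl in place of furan-2-yl on a carbon with a double bond to nitrogen. Among the compounds with values here, no measured pair here shows this exact change, so the expectation rests on the two compounds whose ring on the carbon with a double bond to nitrogen is a six-membered aromatic ring of carbon only bearing a hydroxyl, compound 1 with 530 nM and compound 3 with 4040 nM, both of which are measured numbers. A large step towards stronger inhibition is therefore expected, well beyond the usual scatter, estimated as an at least 33-fold lower number from compound 2 to compound 4 (1.52 log units; beyond the scatter). Compound 4 is estimated at 3000 nM in this assay, with a plausible range from 700 nM to 15000 nM.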

Compound 4, half-maximal inhibitory concentration: 18000 nM
Compound 4: middle estimate off by 6.0-fold (0.78 log units), on the low side; the measured number lies above the stated range.
By their numbers in this assay, from the lowest: compound 1; then compound 3; then compound 4. At a limit, above all of these: compound 2.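

In this assay, going by these compounds alone, putting 3-ethoxy-2-hydroxyphenyl in place of furan-2-yl on a carbon with a double bond to nitrogen gives an at least 5.5-fold lower number from compound 2 to compound 4 (0.74 log units; beyond the scatter), the first step at this place that can be read, and it shows that the read-out responds to this change by more than the usual scatter. Compound 2 stands at a limit of the assay, not at a measured number: the limit of > 100000 nM in this assay, at which 1 of the 4 values shown sits. The change replaces a five-membered aromatic ring with a six-membered aromatic ring of carbon only and brings in a hydroxyl and an ethoxy together, so this single step cannot show which of these parts carries the difference.

The compounds shown leave open what a plain phenyl, or a phenyl bearing only a hydroxyl or only an ethoxy, would give here, and such compounds would be needed to divide the step among its parts. As far as these compounds go, it also remains open how the read-out would respond if the ethoxy gave way to a longer chain such as propoxy, or to a carboxylic acid.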